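A few compounds are considered here, and "the series" means these few. Any claim that something is new, unique, unknown or untested is made for them only; others in the source may bear on it.

The measured compounds are:

Compound 1, `COc1ccc(/C=N/NC(=O)Nc2cc3c(Nc4ccc(F)c(Cl)c4)ncnc3cc2O[C@H]2CCOC2)c(OC)c1OC`; in a functional assay on HepG2 cells (Homo sapiens) for cytotoxicity, read by MTT assay, with a stated time of 72 h (a higher number here means a weaker inhibitor, a lower number a stronger inhibitor), compound 1 gives 29300 nM.
Compound 2, `COc1cc(/C=N/NC(=O)Nc2cc3c(Nc4ccc(F)c(Cl)c4)ncnc3cc2O[C@H]2CCOC2)cc(OC)c1OC`; in this assay compound 2 gives 31200 nM.
Compound 3, `COc1cc2ncnc(Nc3ccc(F)c(Cl)c3)c2cc1NC(=O)N/N=C/c1ccc(OC)c(OC)c1OC`; in this assay compound 3 gives 31200 nM.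

All three numbers lie close together. Compound 1 and compound 2 share a core and differ in one place, (3,4,5-trimethoxyphenyl in place of 2,3,4-trimethoxyphenyl on a carbon with a double bond to nitrogen). That change gave a 1.1-fold higher number from compound 1 to compound 2 (0.03 log units; within the scatter), so the two values cannot be told apart. Compound 1 and compound 3 differ in the core, (methyl in place of oxolan-3-yl on an oxygen on an aromatic ring), and that change gave a 1.1-fold higher number from compound 1 to compound 3 (0.03 log units; within the scatter), again no separation. Compound 3 and compound 2 stand level at the digits reported.

Compound 4, `COc1cc2ncnc(Nc3ccc(F)c(Cl)c3)c2cc1NC(=O)N/N=C/c1cc(OC)c(OC)c(OC)c1`, has not been measured in this assay. It differs from compound 3 as 3,4,5-trimethoxyphenyl in place of 2,3,4-trimethoxyphenyl on a carbon with a double bond to nitrogen; the place of the change reads word for word as for the change from compound 1 to compound 2, so it is the same change, now on the core of compound 3.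

Because a 1.1-fold higher number from compound 1 to compound 2 (0.03 log units; within the scatter) lay within the scatter, the step from compound 3 to compound 4 is expected to be of about the same size, namely a 1.1-fold higher number from compound 3 to compound 4 (0.02 log units; within the scatter). On that basis compound 4 is estimated to give 33000 nM in this assay, with the likely range from 16000 nM to 66000 nM. This rests on a single earlier pair, compound 1 and compound 2, and on nothing else.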

Compound 4, half-maximal inhibitory concentration: 30100 nM
Compound 4: the middle estimate sits 1.1-fold (0.04 log units) above what was measured, and the stated range covers the measured number.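

In this assay, placing 3,4,5-trimethoxyphenyl where 2,3,4-trimethoxyphenyl stood on the core of compound 3 gave a 1.0-fold lower number from compound 3 to compound 4 (0.02 log units; within the scatter), and this step agrees with the one seen on the other core: the same change on two cores in this assay, a 1.1-fold higher number (0.03 log units; within the scatter) from compound 1 to compound 2 and a 1.0-fold lower number (0.02 log units; within the scatter) from compound 3 to compound 4, 1.1-fold (0.04 log units) apart, within the scatter of two such steps. The second change, methyl in place of oxolan-3-yl on an oxygen on an aromatic ring, gave a 1.0-fold lower number from compound 2 to compound 4 (0.02 log units; within the scatter), and it likewise agrees with its earlier counterpart: the same change on two cores in this assay, a 1.1-fold higher number (0.03 log units; within the scatter) from compound 1 to compound 3 and a 1.0-fold lower number (0.02 log units; within the scatter) from compound 2 to compound 4, 1.1-fold (0.04 log units) apart, within the scatter of two such steps. Going by these compounds alone, each change therefore reads the same on both cores, but every step here lies within the scatter, so this shows only that neither change separates the compounds on either core, not that a step of measurable size would carry from one core to another, and two cores are too few to speak for the wider series.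

The compounds shown leave open whether a different group on the carbon with a double bond to nitrogen, such as a phenyl ring bearing an amine or a carboxylic acid, or a longer chain on the oxygen in place of methyl or oxolan-3-yl, would move the number beyond the scatter. They also leave open whether these two changes would stay as small in a different cell line.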